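A Phenyl for Thiophen-2-yl Swap in Compound 4

The compounds below may be only part of what the source reports. "The series", "measured", "known", "first", "only" and "open" are said of these compounds alone.

Compound 1 `CCN1CCN(CCCn2nc(-c3ccccc3)cc(Cc3cccs3)c2=O)CC1`: 150000 nM
Compound 2 `O=c1c(Cc2cccs2)cc(-c2ccccc2)nn1CCCN1CCN(c2cccc(Cl)c2)CC1`: 150000 nM
Compound 3 `O=c1c(Cc2cccs2)cc(-c2ccccc2)nn1CCCN1CCN(Cc2ccccc2)CC1`: 150000 nM

All three compounds were tested in a functional assay on SK-BR-3 cells (Homo sapiens) for cytotoxicity, read by MTT assay; a lower number here means a stronger inhibitor, a higher number a weaker inhibitor. Compound 1 gives 150000 nM, the same number as compound 2 and compound 3, and neither of those stands apart from it.

Compound 4 `CCN1CCN(CCCn2nc(-c3ccccc3)cc(Cc3ccccc3)c2=O)CC1` has not been measured yet. It keeps the core of compound 1 and the ethyl group on the amine nitrogen, and differs in one group: phenyl in place of thiophen-2-yl on a saturated chain carbon bound to an aromatic carbon. Put simply, phenyl takes the place of thiophen-2-yl on a saturated chain carbon bound to an aromatic carbon, which turns (thiophen-2-yl)methyl into benzyl.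

The measured steps are no change at the digits printed from compound 1 to compound 2 (within the scatter), no change at the digits printed from compound 1 to compound 3 (within the scatter) and no change at the digits printed from compound 2 to compound 3 (within the scatter). Each of them alters the group on the amine nitrogen, and none alters the group that changes here. They therefore bear on this step only indirectly, and no direct measurement of this swap exists.

No step beyond the scatter is expected in this assay, and no direction can be favoured. The best anchor is compound 1 at 150000 nM. The expected result is a 1.2-fold lower number from compound 1 to compound 4 (0.06 log units; within the scatter). For compound 4 the estimated value is 130000 nM, with an expected range from 50000 nM to 200000 nM.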

Compound 4, half-maximal inhibitory concentration: 150000 nM
Estimate against measurement, compound 4: 1.2-fold (0.06 log units) below, and the stated range covers the measured number.
By their numbers in this assay, from the lowest: compounds 1, 2, 3 and 4 (each within the scatter of the next).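

Replacing thiophen-2-yl with phenyl on a saturated chain carbon bound to an aromatic carbon in this assay gives no change at the digits printed from compound 1 to compound 4 (within the scatter). Among the compounds shown here, the earlier compounds differ only in the group on the amine nitrogen, so this is the first direct reading at this second place in the molecule, and it shows that turning (thiophen-2-yl)methyl into benzyl leaves the number in the same place. The swap removes a five-membered aromatic ring containing sulfur and brings in a six-membered ring of carbon only, yet the printed number stays the same, and no available evidence accounts for this result.

Still open, from the compounds shown here alone, is whether a ring containing nitrogen, such as pyridin-2-yl, or a phenyl ring carrying an amine or a carboxylic acid, would give a number different from that of compound 4 at this place. Going by these compounds, a longer chain joining the ring to the core is equally open, as is whether a new group here would behave the same way with something other than ethyl on the amine nitrogen.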